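A second nitro group on compound 2

This account rests on a few compounds, and the source may have more. Where it says the series, first, only, none or still open, it means among the compounds named here.

Within the data shown here, in an ADME assay on BHK cells (Mesocricetus auratus) for cytotoxicity, read by MTT assay, with a stated time of 96 h (a lower number here means that less compound is tolerated, a higher number that more compound is tolerated), compound 2 (`O=[N+]([O-])c1ccc(-c2nc3cc(C(F)(F)F)ccc3[nH]2)cc1`) gives 18000 nM, the lower of the two numbers measured so far, while compound 1 (`COc1ccc(-c2nc3cc(C(F)(F)F)ccc3[nH]2)c([N+](=O)[O-])c1`) gives 100000 nM, a gap beyond the scatter. Compound 3 (`O=[N+]([O-])c1ccc(-c2nc3cc(C(F)(F)F)ccc3[nH]2)c([N+](=O)[O-])c1`) is built from compound 2 with one change: nitro in place of hydrogen on an aromatic carbon, ortho to a large group and meta to a nitro group (nitro in place of hydrogen on an aromatic carbon).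

Among the measured compounds shown here, no two measured compounds differ in one place only, so no measured step gives the size of this change directly. For the measured compounds named here, the only hint comes from compound 1, which also carries a nitro group ortho to a large group and stands at 100000 nM. It differs from compound 3 in a second place as well, so the hint is weak. A small move toward more compound being tolerated in this assay is therefore expected, possibly none beyond the scatter. The expected change is a 1.6-fold higher number from compound 2 to compound 3 (0.19 log units; within the scatter). For compound 3 the estimated value is 28000 nM, with an expected range from 9000 nM to 90000 nM.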

Compound 3, half-maximal cytotoxic concentration: 8000 nM
Beside the measured number, compound 3's estimate is 3.5-fold (0.54 log units) above it; the measured number lies below the stated range.
By their numbers in this assay, from the lowest: compound 3; then compound 2; then compound 1.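

In this assay, the added nitro group moves the number down, a 2.3-fold lower number from compound 2 to compound 3 (0.35 log units; beyond the scatter), so a nitro group on this carbon, ortho to a large group, does not by itself go with more compound being tolerated, even though compound 1 carries one and has the highest number of the three. Exchanging methoxy for nitro while that ortho nitro group stays in place gives a much larger move, a 13-fold lower number from compound 1 to compound 3 (1.10 log units; beyond the scatter), so among these compounds the high number of compound 1 goes with its methoxy group and not with its ortho nitro group. Nothing measured here accounts for either step.

These are single steps, each read on one pair of compounds, so they do not show whether the ortho nitro group would lower the number in the same way on a core carrying methoxy in place of the other nitro group. On these data alone, it also remains open where an amine, a methyl group or a carboxylic acid on the carbon ortho to a large group would stand relative to compound 2 in this assay.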